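The source may report more compounds than this note shows. Statements on the series, on what has been measured and on what is new or still open speak of the compounds shown alone.

Measured so far:
compound 1, `Cc1nc2sc(-c3ccc(C(=O)O)cc3)nc2c(=O)[nH]1`: 1%
compound 2, `Cc1nc2sc(-c3ccco3)nc2c(=O)[nH]1`: 37%
compound 3, `Cc1nc2sc(Nc3ccccc3)nc2c(=O)[nH]1`: 24%

All three share one core and were tested in an assay on CHO cells for displacement of a labelled ligand from adenosine receptor A1 (Homo sapiens), read by scintillation counting, with a stated time of 120 min, tested at 1 uM; a lower number here means less inhibition, a higher number more inhibition at the concentration tested (going by the name of the read-out). Among them compound 3 holds the second highest of the three numbers: compound 2 sits above it by a gap beyond the scatter, and compound 1 sits far below it, also beyond the scatter. Compound 4, `Cc1nc2sc(Nc3ccc(Cl)cc3)nc2c(=O)[nH]1`, has not yet been measured. It differs from compound 3 in one place: chloro in place of hydrogen on an aromatic carbon. Within the data shown here, no step between two measured compounds resembles this change, so there is nothing to set a size against. The expected step from compound 3 to compound 4 is small and positive, a number 6 percentage points higher from compound 3 to compound 4 (within the scatter), staying within the scatter. Compound 4 is therefore estimated at 30% in this assay, with a range from 10% to 55%.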

Compound 4, a percentage reported as inhibition, at one concentration (the size of the read-out at that concentration, not a potency): 33%
Compound 4: the middle estimate sits 3 percentage points below what was measured; measured number inside the range.
By their numbers in this assay, from the lowest: compound 1; then compounds 3, 4 and 2 (each within the scatter of the next, the first and the last beyond it).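

The step of a number 9 percentage points higher from compound 3 to compound 4 (within the scatter) comes from chloro in place of hydrogen on an aromatic carbon, para to a large group. This is the first change in a single place among these compounds, and it shows that this position can carry a chlorine atom with no difference that can be told from the usual scatter of repeated measurements. Nothing available bears on the reason for this result.
On these data alone, whether an amine or a carboxylic acid on this same carbon would shift the number beyond the scatter remains open. So does whether chloro on another carbon of this ring would do so.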